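The compounds below may be only part of what the source reports. "The series", "measured", "known", "first", "only" and "open" are said of these compounds alone.

Of the compounds shown here, three sharing one core have been tested in an ADME assay on NIH3T3 cells (Mus musculus) for cytotoxicity, read by XTT assay, with a stated time of 24 h; a lower number here means a stronger inhibitor, a higher number a weaker inhibitor. Compound 1, `Fc1ccc(C2CC(c3ccc(Cl)s3)=NN2c2nc(-c3ccc(C(F)(F)F)cc3)cs2)cc1`, gives > 500 ug/mL in this assay, which is a limit of the assay and not a number. Compound 2, `Cc1ccc(C2=NN(c3nc(-c4ccccc4)cs3)C(c3ccc(F)cc3)C2)s1`, gives > 500 ug/mL in this assay, again only a limit. Compound 3, `Cc1ccc(C2=NN(c3nc(-c4ccc(Br)cc4)cs3)C(c3ccc(F)cc3)C2)s1`, gives > 500 ug/mL in this assay, also a limit. Within the data shown here, the single step between measured compounds, a step that the two limits leave unreadable from compound 2 to compound 3, therefore cannot be sized, since both ends are limits. Compound 3 thus stands at a limit, and the two other values shown are limits too: all three sit at the limit of > 500 ug/mL in this assay, at which 3 of the 3 values shown sit.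

Compound 4, `Cc1ccc(C2=NN(c3nc(-c4ccc(C(F)(F)F)cc4)cs3)C(c3ccc(F)cc3)C2)s1`, differs from compound 3 in one place: trifluoromethyl in place of bromo on an aromatic carbon, para to a large group. Among the measured compounds shown here, no measured step reads on this change, because the only one, a step that the two limits leave unreadable from compound 2 to compound 3, is unreadable. Compound 1 carries the same trifluoromethyl group on the same kind of ring and gives > 500 ug/mL in this assay. Compound 4 is therefore expected to give about 600 ug/mL in this assay, within a range from 350 ug/mL to 1500 ug/mL, most likely reported again only as a limit. The expected step is a step that the limit leaves unreadable from compound 3 to compound 4, none beyond the scatter.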

Compound 4, half-maximal inhibitory concentration: > 500 ug/mL
Compound 4: only a limit was reported (the forecaster's own chance of this, stated with the estimate: 85%); the middle value does not contradict the limit.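

In this assay compound 4 gives > 500 ug/mL, which is again a limit of the assay and not a number. Among these compounds, its steps from compound 1, compound 2 and compound 3 therefore cannot be read, so no new step can be sized: the limit of > 500 ug/mL in this assay, at which 4 of the 4 values shown sit. How strongly any of these compounds acts in this assay, and whether any change on the shared core alters that, stays open.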